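Urea series on PC-9 cells: positional isomer of compound 1

A few compounds are considered here, and "the series" means these few. Any claim that something is new, unique, unknown or untested is made for them only; others in the source may bear on it.

Measured so far:
compound 1 `COc1cc(NC(=O)Nc2cc(Nc3ccc(C)c(F)c3)ncn2)cc(OC)c1`: 77.5%
compound 2 `COc1cc(Nc2cc(NC(=O)Nc3c(Cl)cccc3Cl)ncn2)cc(C(F)(F)F)c1`: 88.5%

In a functional assay on PC-9 cells (Homo sapiens) for inhibition, read by MTT assay, with a stated time of 48 h, tested at 10 uM (on this read-out higher numbers stand for more inhibition at the one concentration tested (going by the name of the read-out) and lower numbers for less inhibition), compound 1 gives 77.5%, the lower of the two numbers shown; compound 2 gives 88.5%, a gap beyond the usual scatter. Within the data shown here, no step between measured compounds that differ in one place is available. Compound 3 `COc1cc(NC(=O)Nc2cc(Nc3cc(C)cc(F)c3)ncn2)cc(OC)c1` differs from compound 1 by 3-fluoro-5-methylphenyl in place of 3-fluoro-4-methylphenyl on a nitrogen on an aromatic ring. For this assay the expected step is a number 2.5 percentage points lower from compound 1 to compound 3 (within the scatter), likely none beyond the scatter, since the same atoms are merely joined differently. Compound 3 is estimated at 75%, expected between 55% and 90%.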

Compound 3, a percentage reported as inhibition, at one concentration (the size of the read-out at that concentration, not a potency): 64.5%
Estimate against measurement, compound 3: 10.5 percentage points above; low and high end bracket the measured number.
By their numbers in this assay, from the lowest: compound 3; then compound 1; then compound 2.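

Swapping 3-fluoro-4-methylphenyl for 3-fluoro-5-methylphenyl in this assay gives a number 13 percentage points lower from compound 1 to compound 3 (beyond the scatter), so the reading at this place on the shared core responds to how the same atoms are joined, not only to which atoms are present. On this core, the 3-fluoro-4-methylphenyl arrangement gives the higher inhibition of the two. No measurement at hand accounts for the difference.

Still open, from the compounds shown here alone, is whether an ethyl or a methoxy group in place of the methyl of 3-fluoro-4-methylphenyl holds the reading. The same question applies to a chlorine in place of its fluorine.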